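The source may hold more compounds than are shown below. What is called first, only, known or untested is meant among the compounds shown, and "the series" means these compounds.

Measured in a functional assay on A-375 cells (Homo sapiens) for inhibition, read by sulforhodamine B assay, with a stated time of 6 days; on this read-out higher numbers stand for weaker inhibition and lower numbers for stronger inhibition:
compound 1 `CNCCNCc1cccc(-c2nc(NC3CCOCC3)c(C)c(-c3cn(C)nc3C)n2)c1`: > 50000 nM
compound 2 `CNCCNCc1cccc(-c2nc(Nc3ccccc3)c(C)c(-c3cccnc3)n2)c1`: 10900 nM

Compound 1 has no number, only a limit of the assay: > 50000 nM. Compound 2 differs from compound 1 in more than one place. In this assay compound 2 gives a true number at 10900 nM.

Compound 3 `CNCCNCc1cccc(-c2nc(NC3CCOCC3)c(C)c(-c3ccc(O)cc3)n2)c1` has 4-hydroxyphenyl in place of 1,3-dimethyl-1H-pyrazol-4-yl on an aromatic carbon of the core of compound 1 (4-hydroxyphenyl in place of 1,3-dimethyl-1H-pyrazol-4-yl on an aromatic carbon). Within the data shown here, no measured pair isolates this change, so its size is an expectation only. With compound 2 at 10900 nM, a reading inside the range of this assay is expected to be reachable in this series. The expected move, an at least 3.3-fold lower number from compound 1 to compound 3 (0.52 log units; beyond the scatter), is towards stronger inhibition, although another limit reading remains possible. For compound 3 the estimated value is 15000 nM, with an expected range from 3000 nM to 50000 nM.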

Compound 3, half-maximal inhibitory concentration: 24100 nM
Compound 3: the middle estimate sits 1.6-fold (0.21 log units) below what was measured, and the stated range covers the measured number.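

In this assay, 4-hydroxyphenyl in place of 1,3-dimethyl-1H-pyrazol-4-yl on the aromatic carbon next to the ring nitrogen gives an at least 2.0-fold lower number from compound 1 to compound 3 (0.31 log units; beyond the scatter). With the (oxan-4-yl)amino group unchanged, this single position is enough to move the series from a limit reading to a true number. The step is only a lower bound, and its full size cannot be read for this reason: the limit of > 50000 nM in this assay, at which 1 of the 3 values shown sits.

The compounds shown do not separate the change of ring from the hydroxyl group, a question that a plain phenyl or a 4-methoxyphenyl on this carbon would address. Also open, going by these compounds, is whether this gain carries over to other groups at the same carbon, such as a 3-pyridyl paired with the (oxan-4-yl)amino group.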